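Replacing 3-(dimethylamino)propyl with butylcarbonyl in compound 3

The compounds below may be only part of what the source reports. "The series", "measured", "known", "first", "only" and "open" are said of these compounds alone.

Values in a functional assay on A-375 cells (Homo sapiens) for cytotoxicity, read by MTT assay; a lower number here means a stronger inhibitor, a higher number a weaker inhibitor:
compound 1 `C#CCOc1cc(/C=C/C(=O)c2ccc(OC)c3c2OC(C)(C)C=C3)ccc1OC`: > 10000 nM (a limit of the assay)
compound 2 `COc1ccc(/C=C/C(=O)c2ccc(OC)c3c2OC(C)(C)C=C3)cc1OCCO`: 9600 nM
compound 3 `COc1ccc(/C=C/C(=O)c2ccc(OC)c3c2OC(C)(C)C=C3)cc1OCCCN(C)C`: 4100 nM

In this assay compound 3 gives the lowest of the two actual numbers (4100 nM), and compound 2 is its nearest neighbour. Compound 4 `CCCCC(=O)Oc1cc(/C=C/C(=O)c2ccc(OC)c3c2OC(C)(C)C=C3)ccc1OC` differs from compound 3 as follows: butylcarbonyl in place of 3-(dimethylamino)propyl on an oxygen on an aromatic ring. Among the compounds with values here, two measured steps bear on this change, both modest and both ending on the 3-(dimethylamino)propyl chain: a 2.3-fold lower number from compound 2 to compound 3 (0.37 log units; beyond the scatter) and an at least 2.4-fold lower number from compound 1 to compound 3 (0.38 log units; beyond the scatter). Compound 4 lacks that chain, so a modest rise in this assay is expected, back towards compound 2 and compound 1. The expected step is a 2.0-fold higher number from compound 3 to compound 4 (0.29 log units; within the scatter). Compound 4 is estimated at 8000 nM, with an expected range from 3500 nM to 16000 nM.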

Compound 4, half-maximal inhibitory concentration: 220 nM
Compound 4: the middle estimate sits 36-fold (1.56 log units) above what was measured; the whole stated range lies above it.
By their numbers in this assay, from the lowest: compound 4; then compound 3; then compound 2. At a limit, above all of these: compound 1.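

Placing butylcarbonyl on this oxygen on an aromatic ring moves the number in this assay much further than any change among the earlier chains, with a 19-fold lower number from compound 3 to compound 4 (1.27 log units; beyond the scatter) and a 44-fold lower number from compound 2 to compound 4 (1.64 log units; beyond the scatter). This position can therefore carry large differences, and the 3-(dimethylamino)propyl chain, the best of the earlier three, is far from the limit of what it allows. Read against a limit, an at least 45-fold lower number from compound 1 to compound 4 (1.65 log units; beyond the scatter) is a floor only: the limit of > 10000 nM in this assay, at which 1 of the 4 values shown sits.

The compounds shown leave open whether the carbonyl on that oxygen or the length of the chain goes with the drop. An acetyl group or a longer acyl chain in its place would separate the two.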